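Series notes: hydrogen in place of methyl

The source may report more compounds than this note shows. Statements on the series, on what has been measured and on what is new or still open speak of the compounds shown alone.

Of the compounds shown here, two have values so far in a functional assay on HCT-116 cells (Homo sapiens) for antiproliferative activity, with a stated time of 72 h; on this read-out higher numbers stand for weaker inhibition and lower numbers for stronger inhibition. Compound 1 (`O=C(COc1ccc(CNC2CC=C(c3c[nH]c4ccc(F)cc34)CC2)c(F)c1)NO`) gives 261 nM, and compound 2 (`Cc1ccc2[nH]cc(C3=CCC(NCc4ccc(OCC(=O)NO)cc4F)CC3)c2c1`) gives 445 nM. These values lie within the scatter of each other, so compound 2 stands level with compound 1 on the present numbers.

Compound 3 (`O=C(COc1ccc(CNC2CC=C(c3c[nH]c4ccccc34)CC2)c(F)c1)NO`) differs from compound 2 by a single change: hydrogen in place of methyl on an aromatic carbon. This is hydrogen in place of methyl on an aromatic carbon, turning 5-methyl-1H-indol-3-yl into 1H-indol-3-yl.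

Within the data shown here, one measured step bears on this change. It swaps fluoro for methyl on the same aromatic carbon and amounts to a 1.7-fold higher number from compound 1 to compound 2 (0.23 log units; within the scatter). Among the measured compounds shown here, no measurement yet shows hydrogen at this carbon. Given the size of that step, no change beyond the scatter is expected in this assay, and any direction remains tentative. The estimated step is a 1.3-fold lower number from compound 2 to compound 3 (0.13 log units; within the scatter), expected to stay within the scatter. For compound 3 the estimated value is 330 nM, with an expected range of 140 nM to 750 nM.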

Compound 3, half-maximal inhibitory concentration: 436 nM
For compound 3 the middle estimate is 1.3-fold (0.12 log units) below the measured one; the range from low to high includes it.
By their numbers in this assay, from the lowest: compounds 1, 3 and 2 (each within the scatter of the next).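

With hydrogen now at this carbon of the six-membered aromatic ring, the series has three substituents there: fluoro, methyl and hydrogen. In this assay, hydrogen in place of methyl gives a 1.0-fold lower number from compound 2 to compound 3 (0.01 log units; within the scatter), and hydrogen in place of fluoro gives a 1.7-fold higher number from compound 1 to compound 3 (0.22 log units; within the scatter), so both steps to the unsubstituted 1H-indol-3-yl compound lie within the scatter, as does the earlier fluoro-to-methyl step, and these three compounds show no measurable dependence on which of the three groups sits at this carbon. No supporting data are available to explain this result.

The compounds shown leave open whether a group of a different kind at this carbon, such as methoxy, an amine, a carboxylic acid or a longer alkyl chain, would produce a step beyond the scatter in this assay. They also leave open whether the same flat response would hold if another part of the shared core were changed at the same time, since all three compounds differ only at this one carbon.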